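Cytotoxicity of indanone analogues: a methoxyphenyl step

The source may hold more compounds than are shown below. What is called first, only, known or untested is meant among the compounds shown, and "the series" means these compounds.

Measured in a functional assay on WRL68 cells (Homo sapiens) for cytotoxicity, read by MTT assay, with a stated time of 24 h; a lower number here means a stronger inhibitor, a higher number a weaker inhibitor:
compound 1 `COc1cc2c(cc1OC)C(c1cc(OC)c(OC)c(OC)c1)CC2=O` gives 196000 nM.
compound 2 `COc1cc2c(c(OC)c1OC)C(c1ccccc1)CC2=O` gives >= 250000 nM, which is a limit of the assay and not a number.

Compound 2 thus stands at the boundary of what this assay reports: the limit of >= 250000 nM in this assay, at which 1 of the 2 values shown sits. Compound 1 sits at a number close to that same boundary. Among the compounds with values here, no pair of measured compounds differs in a single place, so no measured step is available to calibrate a change.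

Compound 3 `COc1cccc(C2CC(=O)c3cc(OC)c(OC)c(OC)c32)c1` is not yet measured. It differs from compound 2 by methoxy in place of hydrogen on an aromatic carbon; cut one bond further out, the same difference reads phenyl to 3-methoxyphenyl. Compound 2 gives only a limit, >= 250000 nM, so nothing in the measured numbers pulls the expectation in either direction. The step of a number no higher from compound 2 to compound 3 (the limit leaves the size open) is expected to be no larger than the scatter, with no preferred direction. Compound 3 is accordingly expected to return a reading at or near the limit in this assay. Compound 3 is estimated at 250000 nM, with a range from 120000 nM to 450000 nM.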

Compound 3, half-maximal inhibitory concentration: >= 250000 nM
Compound 3 gave a limit, no number; the forecaster's own chance of this, stated with the estimate: 60%; the middle value sits exactly at the limit.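

Compound 2 and compound 3 both return a limit of the assay and not a number in this assay, so no step can be read between them: the limit of >= 250000 nM in this assay, at which 2 of the 3 values shown sit. Still open, from the compounds shown here alone, is whether methoxy in place of hydrogen on an aromatic carbon changes the reading in this assay at all, and in which direction.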